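Coumarin-triazole cytotoxicity: from hydroxymethyl to nitro

The source may report more compounds than this note shows. Statements on the series, on what has been measured and on what is new or still open speak of the compounds shown alone.

Compound 1 `COc1ccc(-n2cc(COc3ccc4oc(=O)ccc4c3)nn2)cc1`, 37800 nM
Compound 2 `O=c1ccc2cc(OCc3cn(-c4cccc(CO)c4)nn3)ccc2o1`, "not determined" (no result reported)

In a functional assay on HCT-116 cells (Homo sapiens) for cytotoxicity, read by MTT assay, with a stated time of 48 h (a higher number here means a weaker inhibitor, a lower number a stronger inhibitor), compound 1 gives 37800 nM. Compound 2 has no number in this assay; it gives "not determined" (no result reported), so it stands nowhere on the scale shown. Compound 3 `O=c1ccc2cc(OCc3cn(-c4cccc([N+](=O)[O-])c4)nn3)ccc2o1` carries nitro in place of hydroxymethyl on an aromatic carbon. Going by the values given here, with no step between measured compounds and no number for compound 2, the size of this step is unknown; on the single value of compound 1 alone, a change of no more than the usual scatter is expected, with weak cytotoxicity retained. Compound 3 is expected to give about 25000 nM, within 7000 nM to 90000 nM.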

Compound 3, half-maximal inhibitory concentration: 26900 nM
For compound 3 the middle estimate is 1.1-fold (0.03 log units) below the measured one; the measured number falls inside the stated range.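

In this assay, going by these compounds alone, the one step that can be read is a 1.4-fold lower number from compound 1 to compound 3 (0.15 log units; within the scatter) and it shows that 3-nitrophenyl and 4-methoxyphenyl on the aromatic nitrogen of the shared core give values within the scatter of each other, both in the weak range. The step from compound 2 to compound 3 cannot be read, as compound 2 has no number. No measurement shown bears on this result.

Still open, from the compounds shown here alone, is what hydroxymethyl itself gives here. Also open, going by these compounds, is whether an amine or a carboxylic acid on this ring would move the number beyond the scatter.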